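The compounds below may be only part of what the source reports. "The series", "measured", "known", "first", "only" and "open" are said of these compounds alone.

Compound 2 `c1ccc(-c2ccc3c(NCCCNCc4ccco4)ccnc3c2)cc1` and compound 1 `COc1ccccc1Oc1ccc2c(NCCCNCc3ccco3)ccnc2c1` share a core and differ by 2-methoxyphenoxy in place of phenyl on an aromatic carbon. In an ADME assay on HepG2 cells (Homo sapiens) for cytotoxicity, read by luminescence, CellTiter-Glo and ATP content, with a stated time of 72 h (on this read-out higher numbers stand for an effect only at larger amounts of compound and lower numbers for an effect already at smaller amounts), compound 2 gives 5920 nM, while compound 1 gives 6500 nM, so the step of a 1.1-fold higher number from compound 2 to compound 1 (0.04 log units; within the scatter) is small. Compound 3 `COc1cccc(CNCCCNc2ccnc3cc(-c4ccccc4)ccc23)c1O` carries the same core as compound 2 but a different chain end, the difference being (2-hydroxy-3-methoxyphenyl in place of furan-2-yl on a saturated chain carbon bound to an amine nitrogen); in this assay compound 3 gives 3210 nM, and the step of a 1.8-fold lower number from compound 2 to compound 3 (0.27 log units; within the scatter) stays within the scatter.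

Compound 4 `COc1ccccc1Oc1ccc2c(NCCCNCc3cccc(OC)c3O)ccnc2c1` has not yet been measured in this assay. It differs from compound 3 by 2-methoxyphenoxy in place of phenyl on an aromatic carbon, the same change that turned compound 2 into compound 1, at the same place on the shared core. Because a 1.1-fold higher number from compound 2 to compound 1 (0.04 log units; within the scatter) hardly moved the number, compound 4 is expected to behave much like compound 3, and the estimated step is a 1.1-fold higher number from compound 3 to compound 4 (0.04 log units; within the scatter). For the measured compounds named here, for compound 4 the estimate in this assay is therefore 3500 nM, with an expected range from 1600 nM to 7500 nM, since only one earlier instance of the change supports it.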

Compound 4, half-maximal effective concentration: 11200 nM
Beside the measured number, compound 4's estimate is 3.2-fold (0.51 log units) below it, outside the stated range (above it).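

In this assay, 2-methoxyphenoxy in place of phenyl gives a 3.5-fold higher number from compound 3 to compound 4 (0.54 log units; beyond the scatter), so the size of this change did not carry over from the core with the furan-2-yl chain end to the one with the 2-hydroxy-3-methoxyphenyl chain end: the same change on two cores in this assay, a 1.1-fold higher number (0.04 log units; within the scatter) from compound 2 to compound 1 and a 3.5-fold higher number (0.54 log units; beyond the scatter) from compound 3 to compound 4, 3.2-fold (0.50 log units) apart, beyond the scatter of two such steps. The same four compounds can be read along the other change, 2-hydroxy-3-methoxyphenyl in place of furan-2-yl, which gives a 1.7-fold higher number from compound 1 to compound 4 (0.24 log units; within the scatter), and this step does not match its earlier counterpart either: the same change on two cores in this assay, a 1.8-fold lower number (0.27 log units; within the scatter) from compound 2 to compound 3 and a 1.7-fold higher number (0.24 log units; within the scatter) from compound 1 to compound 4, 3.2-fold (0.50 log units) apart, beyond the scatter of two such steps. The two changes therefore do not add up independently in these four compounds, but this single set of four shows neither why they do not nor whether the same holds for other groups in the series.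

Going by these compounds, it remains open whether a plain phenoxy or a pyridine ring on the same aromatic carbon would follow compound 1 or compound 4. On these data alone, it is equally open how a benzyl chain end without the hydroxyl, or a longer chain between the two amines, would behave with each of these aromatic groups.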